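The source may hold more compounds than are shown below. What is called first, only, known or untested is meant among the compounds shown, and "the series" means these compounds.

Compound 1 `O=C(CCCCC(S)CCS)Nc1cccc(Cl)c1`: "not active" (no number reported)
Compound 2 `O=C(CCCCC(S)CCS)Nc1ccc(F)cc1`: 6.78%
Compound 3 `Cc1cccc(NC(=O)CCCCC(S)CCS)c1`: 5.75%

These results come from a functional assay on KB cells (Homo sapiens) for inhibition, read by MTT assay, with a stated time of 24 h, tested at 0.1 ug/mL; on this read-out higher numbers stand for more inhibition of growth at the one concentration tested and lower numbers for less inhibition of growth. Compound 2 stands at 6.78%, and compound 3, at 5.75%, lies within the usual scatter of it, so the two cannot be told apart. Compound 1 was reported without a number.

The next compound, compound 4 `O=C(CCCCC(S)CCS)Nc1ccc([N+](=O)[O-])cc1`, keeps the shared core and carries nitro in place of fluoro on an aromatic carbon, para to a large group: nitro in place of fluoro on an aromatic carbon. Going by the values given here, no pair of measured compounds differs in one place only, so the data offer no direct guide to the size of this change. In this assay, no step beyond the scatter is expected in either direction, and a report without a number, as for compound 1, remains possible. The expected a number 1.2 percentage points higher from compound 2 to compound 4 (within the scatter) is small. For compound 4 the estimated value is 8%, with an expected range of 1% to 20%.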

Compound 4, percent growth inhibition at one concentration: "not active" (no number reported)
No number was reported for compound 4, and the estimate cannot be compared.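

Going by these compounds alone, with compound 4 at "not active" (no number reported) against compound 2 at 6.78% no step between the two can be read. The compounds shown leave open how large a change nitro in place of fluoro brings to growth inhibition. Nothing shown bears on this result.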